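The source may report more compounds than this note shows. Statements on the series, on what has been measured and on what is new or still open speak of the compounds shown alone.

Working notes on three measured compounds and one still to be run, all in a functional assay on HOP-62 cells (Homo sapiens) for inhibition, read by sulforhodamine B assay, with a stated time of 48 h; on this read-out higher numbers stand for weaker inhibition of growth and lower numbers for stronger inhibition of growth.

Compound 1 `N=C(N)c1ccc(-c2ccc(-c3cc(Cl)cc(Cl)c3)s2)s1` gives 1760 nM in this assay. Compound 3 `N=C(N)c1ccc(-c2ccc(-c3ccc(Cl)cc3)s2)s1` gives 1750 nM. Compound 2 `COc1ccc(-c2ccc(-c3ccc(C(=N)N)o3)o2)cc1` gives 1500 nM; this is the lowest of the three numbers, yet the gap to compound 3 and the gap to compound 1 both fall within the usual scatter of repeated measurements, so the three sit together and no order among them can be read from these numbers.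

Compound 4 `N=C(N)c1ccc(-c2ccc(-c3ccccc3)o2)o1` has not yet been measured. It differs from compound 2 in one place: hydrogen in place of methoxy on an aromatic carbon. For the measured compounds named here, no step between two measured compounds matches this change, so there is no measured precedent for it; the only guide is that the three measured compounds, despite their differences in the outer ring and in the shared core, all sit within the scatter of each other.

On that basis the step of no change at the digits printed from compound 2 to compound 4 (within the scatter) is expected to stay within the scatter in this assay, with no clear direction. Compound 4 is estimated at 1500 nM, with a range from 800 nM to 3000 nM.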

Compound 4, concentration for 50% growth inhibition: 3590 nM
Compound 4: middle estimate off by 2.4-fold (0.38 log units), on the low side, and the stated range ends below it.
By their numbers in this assay, from the lowest: compounds 2, 3 and 1 (each within the scatter of the next); then compound 4.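

Hydrogen in place of methoxy on an aromatic carbon, para to a large group, gives a 2.4-fold higher number from compound 2 to compound 4 (0.38 log units; beyond the scatter) in this assay and so moves the number towards weaker inhibition of growth. The earlier compounds shown here differ from one another in more than one place and could not isolate any single change; this step does, and it shows that at this position methoxy and hydrogen are not interchangeable in this assay, although the step is modest. Nothing available on the compounds accounts for the step, and its origin remains unexplained.

Going by these compounds, only methoxy and hydrogen are compared at this position, so it remains open whether the higher number for compound 4 is particular to losing methoxy or would be matched by other groups there, such as a hydroxyl, an amine or a longer ethoxy chain. On these data alone, it is equally open whether the same change would produce a step of similar size and direction on the core of compound 3, which carries no methoxy group.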